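The compounds below may be only part of what the source reports. "The series", "measured", "known", "first", "only" and "open" are said of these compounds alone.

Working notes on the series. Within the data shown here, in a functional assay on QG-56 cells (Homo sapiens) for antiproliferative activity (on this read-out lower numbers stand for stronger inhibition and higher numbers for weaker inhibition), compound 2 `Cn1cncc1C(O)(c1ccc(C#N)cc1)c1cc2cc([N+](=O)[O-])cc(-c3ccccc3)c2o1` gives 1480 nM, the higher of the two numbers so far. Compound 1 `Cn1cncc1C(O)(c1ccc(C#N)cc1)c1cc2cc([N+](=O)[O-])cc(-c3ccc(C#N)cc3)c2o1` gives 32.6 nM. The next analogue is compound 3 `Cn1cncc1C(O)(c1ccc(C#N)cc1)c1cc2cc([N+](=O)[O-])cc(-c3cccc(F)c3)c2o1`, where phenyl becomes 3-fluorophenyl: fluoro in place of hydrogen on an aromatic carbon. This is fluoro in place of hydrogen on an aromatic carbon, meta to a large group.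

Among the measured compounds shown here, only one measured step bears on this change: a 45-fold higher number from compound 1 to compound 2 (1.66 log units; beyond the scatter). It is large and beyond the scatter, and it shows that a hydrogen in place of cyano on an aromatic carbon can move this assay strongly. For the measured compounds named here, no measured step involves fluoro, so this step gives only weak guidance and its size should not be carried over. A modest shift toward a lower number is expected, at or near the edge of the scatter, and no change at all remains possible. The estimated step is a 1.9-fold lower number from compound 2 to compound 3 (0.27 log units; within the scatter). For compound 3 the expected value is 800 nM, with an estimated range of 200 nM to 2500 nM.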

Compound 3, half-maximal inhibitory concentration: 145 nM
Beside the measured number, compound 3's estimate is 5.5-fold (0.74 log units) above it; the whole stated range lies above it.
By their numbers in this assay, from the lowest: compound 1; then compound 3; then compound 2.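

In this assay the phenyl ring of compound 2 proves highly responsive to a single small substituent: a lone fluoro, meta to a large group, gives a 10-fold lower number from compound 2 to compound 3 (1.01 log units; beyond the scatter) and so moves the read-out strongly with a group other than cyano. Among these compounds, the nitrile of compound 1 is therefore not the only group on this ring that goes with a lower number, although the exchange still leaves a 4.4-fold higher number from compound 1 to compound 3 (0.65 log units; beyond the scatter) and so 3-fluorophenyl does not match 4-cyanophenyl in this assay. Nothing on hand gives a cause for either step, and the numbers establish only their size and direction.

Three aryl groups cannot show whether the large step belongs to fluoro specifically or would also appear with other substituents on this ring, such as chloro, methoxy, an amine or a carboxylic acid. On these data alone, it also remains open how much the outcome depends on where the fluoro sits, and whether the same step would hold on a core carrying a different group in place of the nitro group.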